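The compounds below may be only part of what the source reports. "The series", "measured", "known", "first", "only" and "open" are said of these compounds alone.

Measured so far in an in vitro assay on SH-SY5Y cells for displacement of a labelled ligand from Neuronal acetylcholine receptor; alpha3/beta4 (Homo sapiens); on this read-out higher numbers stand for weaker inhibition and lower numbers for stronger inhibition:
compound 1, `COc1ccccc1Oc1cncc(C2=CC3CNCC(C2)C3)c1`, gives 56 nM;
compound 2, `C1=C(c2cncc(Oc3ccccc3)c2)CC2CNCC1C2`, gives 1.9 nM.

Within the data shown here, compound 2 holds the lowest number of the two; the only neighbour is compound 1, and the step of a 29-fold lower number from compound 1 to compound 2 (1.47 log units; beyond the scatter) lies beyond the scatter. Among the measured compounds shown here, that step is the sole measured change: hydrogen in place of methoxy on an aromatic carbon of the phenoxy group.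

Compound 3, `FC(F)(F)c1cncc(C2=CC3CNCC(C2)C3)c1`, is not yet measured. It differs from compound 2 by trifluoromethyl in place of phenoxy on an aromatic carbon. This change removes the whole phenoxy group that carried the single measured variation, so the step from compound 1 to compound 2 bears on it only loosely: it shows that this assay responds strongly to changes at that part of the molecule, but gives no direction for replacing the group outright. With nothing in the measured pair that speaks directly to a trifluoromethyl at this position, the expectation is set wide and leans toward a higher number; the estimated step is an 11-fold higher number from compound 2 to compound 3 (1.02 log units; beyond the scatter).

For compound 3 in this assay the estimated value is 20 nM, with an expected range from 3 nM to 150 nM.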

Compound 3, inhibition constant: 79 nM
Compound 3: the middle estimate sits 4.0-fold (0.60 log units) below what was measured, within the range that was stated.
By their numbers in this assay, from the lowest: compound 2; then compounds 1 and 3 (each within the scatter of the next).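

In this assay, the earlier pair showed only a change on the phenoxy ring, whereas this result replaces the whole group at the aromatic carbon two atoms from the ring nitrogen: trifluoromethyl in place of phenoxy gives a 42-fold higher number from compound 2 to compound 3 (1.62 log units; beyond the scatter). The low number of compound 2 therefore does not carry over to this smaller group without a ring, so in this pair the shared core alone does not set the read-out and the group at this place still matters. Even so, compound 3, which has no aromatic ring and no oxygen at this place, gives 79 nM, so a phenoxy group is not required for a measurable value in this assay, although the step to it is large.

The compounds shown leave open how an amine, a nitrile or a phenyl ring joined directly to the aromatic carbon would read at this place, and so whether the oxygen, the ring or both account for the difference between compound 2 and compound 3. No measurement at hand accounts for the size of this step.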